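A few compounds are considered here, and "the series" means these few. Any claim that something is new, unique, unknown or untested is made for them only; others in the source may bear on it.

Values in a functional assay on L1210 cells (Mus musculus) for inhibition (on this read-out higher numbers stand for weaker inhibition and lower numbers for stronger inhibition), so far:
compound 1 `Nc1ccn(C/C=C/CCl)c(=O)n1` gives 50000 nM
compound 2 `NC1=NC(N)c2c(ncn2C=C=CCO)N1` gives 60000 nM
compound 3 `Nc1ncnc2c1ncn2CC#CCCl` gives 90000 nM

The three values lie within the scatter of one another, so compound 3 is not separated from compound 1 or compound 2. The unmeasured compound 4 `Nc1ncnc2c1ncn2/C=C/CCO` carries 4-hydroxybut-1-en-1-yl in place of 4-chlorobut-2-yn-1-yl on an aromatic nitrogen. Going by the values given here, no measured step isolates this change. Compound 2, on a different core, also has a hydroxy-bearing chain and gives 60000 nM in this assay, so no step beyond the scatter is expected. The expected change is a 1.1-fold higher number from compound 3 to compound 4 (0.05 log units; within the scatter), with no firm direction. Compound 4 is estimated at 100000 nM (range 40000 nM to 300000 nM)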

Compound 4, half-maximal inhibitory concentration: 100000 nM
Beside the measured number, compound 4's estimate shows no gap at the digits printed, within the range that was stated.
By their numbers in this assay, from the lowest: compounds 1, 2, 3 and 4 (each within the scatter of the next).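

On the shared core, exchanging 4-chlorobut-2-yn-1-yl for 4-hydroxybut-1-en-1-yl on an aromatic nitrogen gives, in this assay, a 1.1-fold higher number from compound 3 to compound 4 (0.05 log units; within the scatter). This substitution replaces chlorine with oxygen and a triple bond with a double bond, adding a hydrogen-bond donor and acceptor without a step beyond the scatter. No supporting data bear on this result.

The step changes the chain end and the unsaturation together, so neither can be read alone. Going by these compounds, whether a chain ending in an amine or a carboxylic acid would separate from compound 3 remains open.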